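Replacing pyridin-4-yl with chloro in compound 4

The source may hold more compounds than are shown below. What is called first, only, known or untested is meant among the compounds shown, and "the series" means these compounds.

- Compound 1 `Cc1ccc(-c2cc(C(=O)N3CCC4(CC3)CC(=O)c3nn(C(C)(C)C)cc3O4)c3ccccc3n2)cc1` gives > 10000 nM, a limit of the assay
- Compound 2 `CC(C)(C)n1cc2c(n1)C(=O)CC1(CCN(C(=O)c3cc(-c4ccc(F)cc4)nc4ccccc34)CC1)O2` gives > 10000 nM, a limit of the assay
- Compound 3 `CC(C)(C)n1cc2c(n1)C(=O)CC1(CCN(C(=O)c3cc(-c4ccncc4)nc4ccccc34)CC1)O2` gives 1650 nM

For the measured compounds named here, in a functional assay on MDA-MB-231 cells (Homo sapiens) for inhibition, read by MTT assay, with a stated time of 72 h (a lower number here means a stronger inhibitor, a higher number a weaker inhibitor), compound 3 gives 1650 nM, the only value of the three that is a number and not a limit. Compound 4 `CC(C)(C)n1cc2c(n1)C(=O)CC1(CCN(C(=O)c3cc(Cl)nc4ccccc34)CC1)O2` carries chloro in place of pyridin-4-yl on an aromatic carbon, next to the ring nitrogen (chloro in place of pyridin-4-yl on an aromatic carbon). Going by the values given here, two measured steps bear on this change: an at least 6.0-fold lower number from compound 1 to compound 3 (0.78 log units; beyond the scatter) and an at least 6.0-fold lower number from compound 2 to compound 3 (0.78 log units; beyond the scatter). Among the compounds with values here, each brought pyridin-4-yl onto this carbon, and no measured compound carries chloro there. Taking that group away is therefore expected to raise the number by a modest step in this assay. The expected change is a 3.6-fold higher number from compound 3 to compound 4 (0.56 log units; beyond the scatter). The estimate for compound 4 is 6000 nM, with an expected range of 2000 nM to 18000 nM.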

Compound 4, half-maximal inhibitory concentration: 9220 nM
The estimate for compound 4 lay 1.5-fold (0.19 log units) below the measured number, and the stated range covers the measured number.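

With chloro on the carbon next to the ring nitrogen, this position now has a second true number in this assay, and the step on removing pyridin-4-yl is a 5.6-fold higher number from compound 3 to compound 4 (0.75 log units; beyond the scatter) and counts as modest. A ring on this carbon is therefore not needed for a measurable number, although pyridin-4-yl gives the lower one. Two further steps give only floors: an at least 1.0-fold lower number from compound 2 to compound 4 (0.03 log units; that floor lies within the scatter) and an at least 1.0-fold lower number from compound 1 to compound 4 (0.03 log units; that floor lies within the scatter) are all they show, and neither floor lies beyond the scatter. Compound 1 and compound 2, where these steps start, both sit at a limit of the assay: the limit of > 10000 nM in this assay, at which 2 of the 4 values shown sit.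

The compounds shown leave open whether the advantage of pyridin-4-yl depends on its ring nitrogen. Unsubstituted phenyl, pyridin-3-yl or an amine such as morpholine on this carbon would help to settle that.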